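The compounds below may be only part of what the source reports. "The series", "measured", "known", "first", "only" and "open" are said of these compounds alone.

Working notes on the series.

Three members have been run in a functional assay on C6 cells (Rattus norvegicus) for cytotoxicity, read by MTT assay, with a stated time of 24 h, tested at 6 ug/mL; a higher number here means a weaker effect of the compound at the concentration tested, a lower number a stronger effect: compound 1 `O=C(CSc1nnnn1-c1ccccc1)N/N=c1/scc(-c2ccc(Br)cc2)n1-c1ccccc1`, compound 2 `O=C(CSc1nnnn1-c1ccccc1)N/N=c1/scc(-c2ccc(Cl)cc2)n1-c1ccccc1` and compound 3 `O=C(CSc1ncccn1)N/N=c1/scc(-c2ccc(Br)cc2)n1-c1ccccc1`. In this assay compound 1 gives 61.8%. Compound 2 gives 77.4%, and compound 3 gives 76.4%; these two values lie within the scatter of each other, so no order between compound 2 and compound 3 is claimed.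

Compound 2 differs from compound 1 by chloro in place of bromo on an aromatic carbon, and that change made a step of a number 15.6 percentage points higher from compound 1 to compound 2 (beyond the scatter). Compound 3 differs from compound 1 at the sulfur instead, by pyrimidin-2-yl in place of 1-phenyl-1H-tetrazol-5-yl on a sulfur, with a step of a number 14.6 percentage points higher from compound 1 to compound 3 (beyond the scatter). Each change on its own thus moves the number upward by a modest, comparable amount.

Compound 4 `O=C(CSc1ncccn1)N/N=c1/scc(-c2ccc(Cl)cc2)n1-c1ccccc1` has not yet been measured in this assay. Going by the values given here, it differs from compound 3 by chloro in place of bromo on an aromatic carbon, which is the same change as the one from compound 1 to compound 2, with the place described in identical words in both cases; the two cores differ as set out for compound 3 against compound 1. The change occurs twice in this set and was measured once.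

The expected step from compound 3 to compound 4 is a number 11.6 percentage points higher from compound 3 to compound 4 (beyond the scatter), set beside the measured a number 15.6 percentage points higher from compound 1 to compound 2 (beyond the scatter); this rests on the step from compound 1 to compound 2 being a number 15.6 percentage points higher from compound 1 to compound 2 (beyond the scatter) and on compound 3 starting from 76.4%, somewhat higher, which leaves less room upward. Compound 4 is therefore expected to give about 88% in this assay, estimated to fall between 73% and 100%.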

Compound 4, a percentage reported as activity, at one concentration (the size of the read-out at that concentration, not a potency): 95.9%
For compound 4 the middle estimate is 7.9 percentage points below the measured one; the range from low to high includes it.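

Chloro in place of bromo on an aromatic carbon gives a number 19.5 percentage points higher from compound 3 to compound 4 (beyond the scatter) in this assay, and this step does not differ from the earlier one on the other core: the same change on two cores in this assay, a number 15.6 percentage points higher (beyond the scatter) from compound 1 to compound 2 and a number 19.5 percentage points higher (beyond the scatter) from compound 3 to compound 4, 3.9 percentage points apart, within the scatter of two such steps. Pyrimidin-2-yl in place of 1-phenyl-1H-tetrazol-5-yl on a sulfur gives a number 18.5 percentage points higher from compound 2 to compound 4 (beyond the scatter), and this change also carries across the two cores: the same change on two cores in this assay, a number 14.6 percentage points higher (beyond the scatter) from compound 1 to compound 3 and a number 18.5 percentage points higher (beyond the scatter) from compound 2 to compound 4, 3.9 percentage points apart, within the scatter of two such steps. Within these four compounds, each change therefore moves the number upward by a similar amount whichever form the other site carries, but each comparison rests on only two steps, at a single concentration and in one cell assay, so it shows neither that the pattern extends to other cores nor why the number moves.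

The compounds shown leave open whether fluoro or methoxy in place of the bromo or chloro on that aromatic carbon would move the number in the same direction and by a similar amount. They also leave open whether an amine or a carboxylic acid in place of the pyrimidin-2-yl on the sulfur would combine with the chloro change in the same additive way.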